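Permeability notes: cyclohexyl in place of the benzyl substituent

This account rests on a few compounds, and the source may have more. Where it says the series, first, only, none or still open, it means among the compounds named here.

Compound 3 `COc1cccc(CNCCCNc2ccnc3cc(Cc4cccc(C(F)(F)F)c4)ccc23)c1O` stands in an ADME assay for permeability, using PAMPA, with a stated time of 30 min, at pH 7.4 (on this read-out lower numbers stand for lower permeability and higher numbers for higher permeability), at 23 10^-6 cm/s. It is level with the two other measured members: compound 1 `COc1cccc(CNCCCNc2ccnc3cc(Cc4ccc(C#N)cc4)ccc23)c1O` gives 23 10^-6 cm/s in this assay, and compound 2 `COc1cccc(CNCCCNc2ccnc3cc(CC(C)C)ccc23)c1O` gives 23 10^-6 cm/s. The three steps among them confirm this: no change at the digits printed from compound 1 to compound 2 (within the scatter), no change at the digits printed from compound 1 to compound 3 (within the scatter) and no change at the digits printed from compound 2 to compound 3 (within the scatter). Three quite different substituents, 4-cyanophenyl, isopropyl and 3-(trifluoromethyl)phenyl, thus leave the read-out where it is.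

Compound 4 `COc1cccc(CNCCCNc2ccnc3cc(C4CCCCC4)ccc23)c1O` is the next member, differing from compound 3 as follows: cyclohexyl in place of 3-(trifluoromethyl)benzyl on an aromatic carbon. All three measured steps bear on this change, since each swaps the substituent at this part of the shared core, and each came out within the scatter. The entering cyclohexyl is a saturated ring of six carbon atoms, closest in kind to the isopropyl of compound 2, whose value in this assay matched the aryl-bearing compounds. The expectation for compound 4 is therefore no step beyond the scatter, no change at the digits printed from compound 3 to compound 4 (within the scatter). Compound 4 is estimated at 23 10^-6 cm/s in this assay, with a range from 12 10^-6 cm/s to 42 10^-6 cm/s.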

Compound 4, apparent permeability: 23 10^-6 cm/s
Compound 4: the middle estimate sits on the measured number at the digits printed; the range from low to high includes it.
By their numbers in this assay, from the lowest: compounds 1, 2, 3 and 4 (each within the scatter of the next).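

In this assay, cyclohexyl in place of 3-(trifluoromethyl)benzyl gives no change at the digits printed from compound 3 to compound 4 (within the scatter) and shows that the read-out is level when a non-aromatic ring sits directly on the aromatic carbon, whereas compounds 1, 2 and 3 all carry a saturated chain carbon at this place. The other two comparisons agree, with cyclohexyl in place of isobutyl giving no change at the digits printed from compound 2 to compound 4 (within the scatter) and cyclohexyl in place of 4-cyanobenzyl giving no change at the digits printed from compound 1 to compound 4 (within the scatter), so at this position the read-out has now stayed level across a substituent of 11 heavy atoms and one of 6, and with or without an aromatic ring in the group. No supporting measurement is available to explain this flat result.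

Among these compounds, all groups at this position so far lack hydrogen-bond donors and charge, so it remains open whether a primary amine, a carboxylic acid or a morpholine ring here would stay level with these compounds. From the compounds shown here alone, it also remains open whether the same level in this assay would hold with a longer chain between the shared core and the cyclohexyl ring, or with a change elsewhere in the shared core.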